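The source may hold more compounds than are shown below. What is called first, only, known or untested is meant among the compounds shown, and "the series" means these compounds.

Measured so far in a functional assay on DU-145 cells (Homo sapiens) for inhibition, read by trypan blue exclusion, with a stated time of 96 h; on this read-out higher numbers stand for weaker inhibition of growth and lower numbers for stronger inhibition of growth:
- Compound 1 `COc1ccc(/C=C(/Sc2ccc(Br)cc2)C(=O)c2ccc(Br)cc2)cc1`: 25000 nM
- Compound 2 `COc1ccc(/C=C(/Sc2ccc(Br)cc2)C(=O)c2ccc(Br)cc2)c(F)c1`: 20000 nM

Compound 2, at 20000 nM, sits within the scatter of compound 1, so the two numbers cannot be told apart. Compound 3 `O=C(/C(=C\c1ccc(Cl)cc1)Sc1ccc(Br)cc1)c1ccc(Br)cc1` has not yet been measured. It carries 4-chlorophenyl in place of 2-fluoro-4-methoxyphenyl on a double-bonded chain carbon bound to a double-bonded chain carbon. Within the data shown here, only one measured step touches this group, a 1.3-fold lower number from compound 1 to compound 2 (0.10 log units; within the scatter), and it stays within the scatter. Among the measured compounds shown here, no measured step covers the loss of the methoxy group or the arrival of the chlorine, so the evidence is thin. No shift beyond the scatter is therefore expected in this assay, and the expected change is a 1.1-fold lower number from compound 2 to compound 3 (0.05 log units; within the scatter). Compound 3 is estimated at 18000 nM, with an expected range of 7000 nM to 40000 nM.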

Compound 3, concentration for 50% growth inhibition: 1000 nM
For compound 3 the middle estimate is 18-fold (1.26 log units) above the measured one; measured number outside the range, below it.
By their numbers in this assay, from the lowest: compound 3; then compounds 2 and 1 (each within the scatter of the next).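

In this assay this position on a double-bonded chain carbon proves able to shift growth inhibition far beyond the scatter, something the fluoro step alone had not revealed: 4-chlorophenyl in place of 2-fluoro-4-methoxyphenyl brings a 20-fold lower number from compound 2 to compound 3 (1.30 log units; beyond the scatter) in the direction of stronger inhibition. The simpler exchange of chloro in place of methoxy on an aromatic carbon brings a 25-fold lower number from compound 1 to compound 3 (1.40 log units; beyond the scatter) and so is enough by itself for a large gain, with no fluoro involved. Nothing available here accounts for this gain.

The compounds shown leave open whether the gain comes from the arrival of the chlorine or from the loss of the methoxy group. They also leave open whether a bromine, a trifluoromethyl group or an amine on that aromatic carbon would act as the chlorine does.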